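This account rests on a few compounds, and the source may have more. Where it says the series, first, only, none or still open, it means among the compounds named here.

Two sulfonamides built on the same core have been tested in a functional assay on A549 cells (Homo sapiens) for antiproliferative activity, with a stated time of 2 days; on this read-out lower numbers stand for stronger inhibition and higher numbers for weaker inhibition. Compound 1, `Cc1ccc(S(=O)(=O)Nc2ccc(-c3ccccc3)c3cccnc23)cc1`, carries a phenyl ring on the core and gives 7220 nM. Compound 2, `Cc1ccc(S(=O)(=O)Nc2cc(Oc3cc(F)cc(F)c3)cc3cccnc23)cc1`, instead carries a 3,5-difluorophenoxy group and gives 2940 nM. Of these two numbers, compound 2 has the lower one, and the gap to compound 1 is wider than the usual scatter of this assay, so compound 2 counts as the more potent of the pair on the evidence so far. The two compounds differ in more than one place, so the numbers alone cannot say which part of the change matters.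

Compound 3, `Cc1ccc(S(=O)(=O)Nc2cc(Oc3cccc(C#N)c3)cc3cccnc23)cc1`, keeps everything in compound 2 except for one exchange: 3-cyanophenyl in place of 3,5-difluorophenyl on an oxygen on an aromatic ring. For the measured compounds named here, no measured pair shows what such an exchange does here, so no direction can be read from the data. The expected step is a 1.2-fold higher number from compound 2 to compound 3 (0.08 log units; within the scatter), which would mean little change beyond the scatter. Compound 3 is therefore expected to give about 3500 nM, somewhere between 1200 nM and 10000 nM.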

Compound 3, half-maximal inhibitory concentration: "not active" (no number reported)
No number was reported for compound 3; there is nothing to compare the estimate with.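

For the compounds shown here, compound 3 comes without a number in this assay, so no step from compound 2 to compound 3 can be read. Nothing available offers an explanation for this result. The compounds shown leave open how 3-cyanophenoxy compares in size of effect with 3,5-difluorophenoxy on the shared core.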